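The source may report more compounds than this note shows. Statements on the series, on what has been measured and on what is new or still open speak of the compounds shown alone.

Working notes on the series. Compound 3 `CC(C)=CCc1cc(/C=C2\OC(=O)C(c3ccc(O)cc3O)=C2O)ccc1O` gives 2400 nM in a functional assay on J774.1 cells (Mus musculus), read by LDH release, with a stated time of 1 h, in the presence of a further agent that is not named here (on this read-out higher numbers stand for weaker inhibition and lower numbers for stronger inhibition), the lowest of the three numbers in hand. Compound 2 `CC(C)=CCc1cc(C2=C(O)/C(=C/c3ccc(O)c(CCC(C)(C)O)c3)OC2=O)c(O)cc1O` gives 3100 nM in this assay, which lies within the scatter of compound 3, so no order between the two can be claimed. Compound 1 `CC(C)=CCc1cc(C2=C(O)/C(=C/c3ccc(O)c(CC(O)C(C)(C)O)c3)OC2=O)c(O)cc1O` gives 7400 nM in this assay, beyond the scatter from compound 3. Among the compounds with values here, the one measured step, a 2.4-fold lower number from compound 1 to compound 2 (0.38 log units; beyond the scatter), concerns a change on a saturated chain and does not bear directly on what follows.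

Compound 4 `CC(C)=CCc1cc(/C=C2\OC(=O)C(c3cc(CC=C(C)C)c(O)cc3O)=C2O)ccc1O` differs from compound 3 by 3-methylbut-2-en-1-yl in place of hydrogen on an aromatic carbon. Within the data shown here, no measured pair in this set shows what 3-methylbut-2-en-1-yl in place of hydrogen on an aromatic carbon does, so the expectation rests on the narrow spread among compounds 2 and 3 and is for no step beyond the scatter, or a small one toward a lower number. On that basis compound 4 is estimated at 1800 nM in this assay, in the range 600 nM to 5500 nM, an expected step of a 1.3-fold lower number from compound 3 to compound 4 (0.12 log units; within the scatter).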

Compound 4, half-maximal inhibitory concentration: 3000 nM
Estimate against measurement, compound 4: 1.7-fold (0.22 log units) below, within the range that was stated.
By their numbers in this assay, from the lowest: compounds 3, 4 and 2 (each within the scatter of the next); then compound 1.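

At this position, on an aromatic carbon ortho to one hydroxy group and para to another, 3-methylbut-2-en-1-yl in place of hydrogen leaves no readable change in this assay (a 1.3-fold higher number from compound 3 to compound 4 (0.10 log units; within the scatter)), so the added chain neither gains nor loses anything measurable here. The comparison at the other prenylated site reads the same way for 2-methylprop-1-en-1-yl in place of 2-hydroxy-2-methylpropyl (a 1.0-fold lower number from compound 2 to compound 4 (0.01 log units; within the scatter)). Only 2-methylprop-1-en-1-yl in place of 1,2-dihydroxy-2-methylpropyl gives a step beyond the scatter, and a modest one (a 2.5-fold lower number from compound 1 to compound 4 (0.39 log units; beyond the scatter)).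

No supporting data bear on why the added chain makes no readable difference. Going by these compounds, whether an amine, a carboxylic acid or a longer chain such as geranyl on this aromatic carbon would move the number stays open.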